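This account rests on a few compounds, and the source may have more. Where it says the series, first, only, none or still open, it means among the compounds named here.

In a functional assay on MCF7 cells (Homo sapiens) for cytotoxicity, read by MTT assay, with a stated time of 72 h (a lower number here means a stronger inhibitor, a higher number a weaker inhibitor), two compounds that share a core have been measured so far. Compound 1 `O=C(/C=C/c1ccc([N+](=O)[O-])cc1)Nc1cc2c(Nc3ccc(F)c(Cl)c3)ncnc2cc1O[C@H]1CCOC1` gives 26700 nM, and compound 2 `COc1cc(/C=C/C(=O)Nc2cc3c(Nc4ccc(F)c(Cl)c4)ncnc3cc2O[C@H]2CCOC2)cc(OC)c1O` gives 30500 nM. These two numbers lie within the usual scatter of repeated measurements, so the data do not rank compound 2 against compound 1.

The next compound, compound 3 `COc1ccc(/C=C/C(=O)Nc2cc3c(Nc4ccc(F)c(Cl)c4)ncnc3cc2O[C@H]2CCOC2)cc1`, differs from compound 2 in one place: 4-methoxyphenyl in place of 4-hydroxy-3,5-dimethoxyphenyl on a double-bonded chain carbon bound to a double-bonded chain carbon. It has 4-methoxyphenyl in place of 4-hydroxy-3,5-dimethoxyphenyl on a double-bonded chain carbon bound to a double-bonded chain carbon.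

Going by the values given here, only one measured step bears on this change, since it falls at the same place: a 1.1-fold higher number from compound 1 to compound 2 (0.06 log units; within the scatter). In that step, 4-hydroxy-3,5-dimethoxyphenyl took the place of 4-nitrophenyl. Among the compounds with values here, one step is thin evidence, and no measured compound yet carries the 4-methoxyphenyl group. Even so, the only swap seen at this place lies within the scatter, so no step beyond the scatter is expected in this assay, in either direction. The expected step is a 1.1-fold lower number from compound 2 to compound 3 (0.02 log units; within the scatter). Compound 3 is estimated at 29000 nM, with an expected range from 14000 nM to 60000 nM.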

Compound 3, half-maximal inhibitory concentration: 5070 nM
For compound 3 the middle estimate is 5.7-fold (0.76 log units) above the measured one; measured number below the stated range.
By their numbers in this assay, from the lowest: compound 3; then compounds 1 and 2 (each within the scatter of the next).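

The first two compounds gave no sign that the group at this place, on a double-bonded chain carbon bound to a double-bonded chain carbon, could shift the result in this assay, but the new compound shows that it can, with a 6.0-fold lower number from compound 2 to compound 3 (0.78 log units; beyond the scatter). The second new step, a 5.3-fold lower number from compound 1 to compound 3 (0.72 log units; beyond the scatter), has methoxy in place of nitro on an aromatic carbon and shows the same separation, so 4-methoxyphenyl stands apart from both 4-nitrophenyl and 4-hydroxy-3,5-dimethoxyphenyl, while those two remain within the scatter of each other. No measurement available here accounts for this difference.

Going by these compounds, compound 2 also carries methoxy groups, yet its number stays within the scatter of compound 1, so methoxy alone does not go with a lower number across these compounds, and it remains open which feature of the 4-methoxyphenyl group matters. The compounds shown also leave open where an unsubstituted phenyl group would fall, and whether an amine or a longer alkoxy chain in place of the methoxy would keep the lower number of compound 3.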